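Hydroxyl placement in the shared core

A few compounds are considered here, and "the series" means these few. Any claim that something is new, unique, unknown or untested is made for them only; others in the source may bear on it.

Compound 1 `Oc1ccc(-c2cc(-c3cccc(C(F)(F)F)c3)cc(-c3ccc(O)cc3)n2)cc1` gives only a limit in a functional assay on T47D cells (Homo sapiens) for inhibition (a lower number here means a stronger inhibitor, a higher number a weaker inhibitor), > 50000 nM. Among the compounds with values here, compound 2 `Oc1ccc(-c2cc(-c3cccc(OC(F)(F)F)c3)cc(-c3cccc(O)c3)n2)cc1` is the sole compound with a number in this assay, at 5040 nM. A comparison with compound 1 is therefore not possible. Compound 3 `Oc1ccc(-c2cc(-c3cccc(OC(F)(F)F)c3)cc(-c3ccc(O)cc3)n2)cc1` carries 4-hydroxyphenyl in place of 3-hydroxyphenyl on an aromatic carbon. Within the data shown here, no step between measured compounds covers this change, so the effect in this assay is expected to lie within the scatter or amount to a modest weakening. The expected step is a 1.4-fold higher number from compound 2 to compound 3 (0.14 log units; within the scatter). Compound 3 is accordingly estimated at 7000 nM, with a range from 2500 nM to 25000 nM.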

Compound 3, half-maximal inhibitory concentration: > 50000 nM
Compound 3: no number, only a limit; the forecaster's own chance of this, stated with the estimate: 15%; middle value at least 7.1-fold (0.85 log units) away from the limit.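

In this assay, 4-hydroxyphenyl in place of 3-hydroxyphenyl on the aromatic carbon next to the ring nitrogen gives an at least 9.9-fold higher number from compound 2 to compound 3 (0.99 log units; beyond the scatter), so this position responds to the change even though the two groups have the same atoms, joined differently. On these data alone, the value of compound 3 is a limit, so the full size of this step remains unknown. The step between trifluoromethyl and trifluoromethoxy cannot be read, since both values are limits: the limit of > 50000 nM in this assay, at which 2 of the 3 values shown sit.

Open, as far as these compounds go, is whether an amine or a carboxylic acid in place of the hydroxyl on this ring would keep activity. Also open, from the compounds shown here alone, is how 3-hydroxyphenyl behaves alongside trifluoromethyl.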